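This account rests on a few compounds, and the source may have more. Where it says the series, first, only, none or still open, it means among the compounds named here.

Compound 1, `CC(C)C(=O)Nc1cccc(S(=O)(=O)Oc2ccccc2C(C)C)c1`, and compound 2, `CC(C)c1ccccc1OS(=O)(=O)c1cccc(NC(=O)C(C)(C)C)c1`, share one core, and in a functional assay on M21 cells (Homo sapiens) for antiproliferative activity, read by sulforhodamine B assay, with a stated time of 48 h (a lower number here means a stronger inhibitor, a higher number a weaker inhibitor), compound 1 gives 17000 nM while compound 2 gives 13000 nM. The change between them is methyl in place of hydrogen on a saturated chain carbon bound to a carbonyl carbon and two saturated chain carbons, and it made a 1.3-fold lower number from compound 1 to compound 2 (0.12 log units; within the scatter). Compound 3, `CC(=O)Nc1ccc(S(=O)(=O)Oc2ccccc2C(C)C)cc1`, rests on a different core; the difference between the two cores is not broken down here. In this assay compound 3 gives 21000 nM. The unmeasured compound 4, `CCC(=O)Nc1ccc(S(=O)(=O)Oc2ccccc2C(C)C)cc1`, arises from compound 3 by methyl in place of hydrogen on a saturated chain carbon bound to a carbonyl carbon. This is the same kind of change as that from compound 1 to compound 2, though here the saturated chain carbon is bound to a carbonyl carbon only, and not also to two saturated chain carbons. Since the earlier step stayed within the scatter, compound 4 is expected to sit close to compound 3, with a step of about a 1.2-fold lower number from compound 3 to compound 4 (0.09 log units; within the scatter) expected in this assay, because compound 2, at 13000 nM, stood near compound 1. Compound 4 is therefore estimated at 17000 nM in this assay, most likely between 8000 nM and 40000 nM.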

Compound 4, half-maximal inhibitory concentration: 11000 nM
Compound 4: middle estimate off by 1.5-fold (0.19 log units), on the high side; measured number inside the range.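

In this assay, the change from acetamido to propanoylamino gives a 1.9-fold lower number from compound 3 to compound 4 (0.28 log units; within the scatter). Set beside the earlier step, methyl in place of hydrogen gives steps on the two cores that cannot be told apart: the same change on two cores in this assay, a 1.3-fold lower number (0.12 log units; within the scatter) from compound 1 to compound 2 and a 1.9-fold lower number (0.28 log units; within the scatter) from compound 3 to compound 4, 1.5-fold (0.16 log units) apart, within the scatter of two such steps. This is consistent with the change carrying from one core to the other, but only in the limited sense that neither step moves the number beyond the scatter; with just two pairs, it does not show that the change has a real effect on either core, nor that the same would hold on any further core.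

The compounds shown leave open whether a longer chain on the carbonyl, such as a butanoyl or hexanoyl group, would move the number beyond the scatter on either core. They also leave open what a cyclopropyl ring, a phenyl ring or an amine in that same place would do.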